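The source may report more compounds than this note shows. Statements on the series, on what has been measured and on what is new or still open speak of the compounds shown alone.

Measured so far:
- compound 1, `C=CCn1c(=O)n(C2CN(CCCC)CC(CO)O2)c2nc(N)nc(O)c21`: 52%
- compound 2, `C=CCn1c(=O)n([C@@H]2O[C@H](CO)[C@H]3OC(C)(CCC(=O)NC)O[C@H]32)c2nc(N)nc(O)c21`: 0%
- compound 3, `CN(C)CCCn1c(=O)n(C2OC(CO)[C@@H](O)[C@H]2O)c2nc(N)nc(O)c21`: 63%

The three compounds were tested in a functional assay on the whole organism with Mus musculus as the target; a lower number here means a smaller maximal response, a higher number a larger maximal response. Among them, compound 3 stands highest with 63%. The nearest number belongs to compound 1, whose 52% lies lower by a margin beyond the usual scatter of repeated measurements. Compound 2 is furthest away: its 0% sits far below compound 3, again well beyond the scatter. No two of these compounds differ in just one place, so no single-point step can be read from them.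

The next compound to be measured is compound 4, `CCCCCCn1c(=O)n(C2OC(CO)[C@@H](O)[C@H]2O)c2nc(N)nc(O)c21`. It differs from compound 3 in one spot: propyl in place of dimethylamino on a saturated chain carbon, three bonds along the chain from an aromatic nitrogen. Among the compounds with values here, nothing among the measured compounds shows what this particular change does in this assay, so the expectation rests only on the fact that the shared core and the sugar-like part stay the same while one end of the chain changes. A modest step is expected, more likely downward than upward, and possibly within the scatter. Compound 4 is therefore expected to reach 50%, with a range from 25% to 75%, meaning an estimated step of a number 13 percentage points lower from compound 3 to compound 4 (beyond the scatter).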

Compound 4, largest response reached (reported as maximal response), in percent of the reference or control that the assay uses: 11%
Beside the measured number, compound 4's estimate is 39 percentage points above it, and the stated range ends above it.
By their numbers in this assay, from the lowest: compound 2; then compound 4; then compound 1; then compound 3.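

In this assay, this position proves far from indifferent to what ends the chain: putting propyl in place of dimethylamino, on a saturated chain carbon, three bonds along the chain from an aromatic nitrogen, gives a large change, a number 52 percentage points lower from compound 3 to compound 4 (beyond the scatter). The two groups match in size, with 3 heavy atoms each, no ring and no net charge, so the step goes with a change of atoms rather than a change in their count: a nitrogen and its hydrogen-bond acceptor leave, and carbon takes their place. The earlier compounds shown here could not show this, as no two of them differed in one place.

Nothing available explains why the response drops with this swap, so the step stands as an observation without a stated cause. On these data alone, it remains open whether the nitrogen alone carries the difference, and how a primary amine, a morpholine or a carboxylic acid at the end of the same chain, or a longer chain in place of hexyl, would behave in this assay.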